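This account rests on a few compounds, and the source may have more. Where it says the series, first, only, none or still open, it means among the compounds named here.

Series around a shared core carrying an acylhydrazone aryl group, compared in a functional assay on A549 cells (Homo sapiens) for cytotoxicity, read by MTT assay, with a stated time of 72 h; on this read-out higher numbers stand for weaker inhibition and lower numbers for stronger inhibition. Compound 1 `COc1ccc(OC)c(/C=N/NC(=O)Nc2ccc(Oc3ccnc(-c4nncn4CCN(C)C)c3)c(F)c2)c1` gives 1950 nM. Compound 2 `CN(C)CCn1cnnc1-c1cc(Oc2ccc(NC(=O)N/N=C/c3ccccc3O[N+](=O)[O-])cc2F)ccn1` gives 1200 nM. Compound 3 `CN(C)CCn1cnnc1-c1cc(Oc2ccc(NC(=O)N/N=C/c3ccc(Cl)cc3)cc2F)ccn1` gives 780 nM. On these three numbers compound 1 stands highest: a 1.6-fold lower number from compound 1 to compound 2 (0.21 log units; within the scatter), and a 2.5-fold lower number from compound 1 to compound 3 (0.40 log units; beyond the scatter). Between the other two, a 1.5-fold lower number from compound 2 to compound 3 (0.19 log units; within the scatter).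

Compound 4 `CN(C)CCn1cnnc1-c1cc(Oc2ccc(NC(=O)N/N=C/c3ccc(O)c(F)c3)cc2F)ccn1` is not yet measured. Against compound 1 its only change is at the aryl group on the acylhydrazone: 3-fluoro-4-hydroxyphenyl in place of 2,5-dimethoxyphenyl on a carbon with a double bond to nitrogen

Both measured steps from compound 1 bear on this, since each replaces the same 2,5-dimethoxyphenyl at the same place: one swap stayed within the scatter, the other gave a modest lowering. Nothing measured carries a 3-fluoro-4-hydroxyphenyl or a hydrogen-bond donor at this position, so the direction rests on the general observation that leaving 2,5-dimethoxyphenyl has so far lowered or left the number unchanged. The expected step is a 1.6-fold lower number from compound 1 to compound 4 (0.21 log units; within the scatter), a lowering no larger than that seen with compound 3 in this assay. Compound 4 is therefore estimated at 1200 nM, with a range from 500 nM to 3000 nM.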

Compound 4, half-maximal inhibitory concentration: 13400 nM
The estimate for compound 4 lay 11-fold (1.05 log units) below the measured number; measured number above the stated range.
By their numbers in this assay, from the lowest: compounds 3, 2 and 1 (each within the scatter of the next, the first and the last beyond it); then compound 4.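

In this assay, the place on the carbon with a double bond to nitrogen does not accept every replacement of 2,5-dimethoxyphenyl: with 3-fluoro-4-hydroxyphenyl there is a 6.9-fold higher number from compound 1 to compound 4 (0.84 log units; beyond the scatter), whereas the earlier replacements gave a modest lowering or stayed within the scatter. The same group also separates compound 4 from the two lower compounds, with a 17-fold higher number from compound 3 to compound 4 (1.24 log units; beyond the scatter) and an 11-fold higher number from compound 2 to compound 4 (1.05 log units; beyond the scatter), so this aryl group spans a wider range than the first three compounds showed. No measurement at hand accounts for this rise.

Going by these compounds, the hydroxyl and the fluorine enter together in compound 4, and which of them goes with the higher number remains open. A phenyl carrying only one of them would separate the two, and an amine or a carboxylic acid on this ring would show whether other groups follow the same direction.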